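A few compounds are considered here, and "the series" means these few. Any claim that something is new, unique, unknown or untested is made for them only; others in the source may bear on it.

Measured compounds:
compound 1 `CC1(c2ccccc2)CC(=O)N(CC(=O)N2CCN(c3ccccc3)CC2)C1=O`: 100 mg/kg
compound 2 `CC1(c2ccccc2)CC(=O)N(CC(=O)N2CCN(c3ccccc3Cl)CC2)C1=O`: "not active" (no number reported)
compound 3 `COc1ccccc1N1CCN(C(=O)CN2C(=O)CC(C)(c3ccccc3)C2=O)CC1`: "not active" (no number reported)

In a functional assay on the whole organism (strain CD-1) with Mus musculus as the target, with a stated time of 0.5 h (on this read-out lower numbers stand for an effect already at smaller amounts and higher numbers for an effect only at larger amounts of compound), compound 1 gives 100 mg/kg. Compound 2, in this assay, is reported only as "not active" (no number reported), with no number attached. Compound 3 likewise gives "not active" (no number reported) in this assay, and no dose is stated for it. Compound 3 therefore stands apart from compound 1 without a single number to its name, and a second entry of the set, compound 2, shares this position. Among the compounds with values here, no measured pair here differs in one place, so no step can be read from the data.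

Compound 4 `CC1(c2ccccc2)CC(=O)N(CC(=O)N2CCN(c3ccc(Cl)c(Cl)c3)CC2)C1=O` has not been measured. It differs from compound 3 in one place: 3,4-dichlorophenyl in place of 2-methoxyphenyl on an amine nitrogen in a ring. Within the data shown here, because compound 3 gives "not active" (no number reported), no numerical step to compound 4 can be stated; the only numbered anchor among the compounds is compound 1 with 100 mg/kg, and the two entries without a number lie around it. The account therefore expects compound 4 to show either no activity or an effect only at large amounts in this assay. Compound 4 is estimated at 300 mg/kg, expected between 100 mg/kg and 1000 mg/kg.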

Compound 4, minimum effective dose: "not active" (no number reported)
The entry for compound 4 holds no number; there is nothing to compare the estimate with.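

Within the data shown here, compound 3 and compound 4 are both reported without a number, so no step between them can be read. Nothing in the data bears on this result. The compounds shown leave open whether the change from 2-methoxyphenyl to 3,4-dichlorophenyl has any effect on the dose needed.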